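This account rests on a few compounds, and the source may have more. Where it says the series, first, only, none or still open, it means among the compounds named here.

Compound 1 `Cn1nccc1-c1cc(C(F)(F)F)ccc1[C@H]1CCOc2cc(S(=O)(=O)Nc3ccncn3)ccc21`: 1.8
Compound 2 `O=S(=O)(Nc1ccncn1)c1ccc2c(c1)OCC[C@@H]2c1ccc(C(F)(F)F)cc1-c1ccc(F)cn1`: 3
Compound 3 `Cn1nccc1-c1cc(C(F)(F)F)ccc1[C@@H]1CCOc2cc(S(=O)(=O)Nc3nccs3)ccc21`: 2.2

In a physicochemical assay for lipophilicity (a higher number here means a more lipophilic compound, a lower number a more polar compound), compound 1 stands lowest of the three measured compounds; compound 3 lies beyond the scatter above it, and compound 2 further above still. Compound 4 `Cn1nccc1-c1cc(C(F)(F)F)ccc1[C@H]1CCOc2cc(S(=O)(=O)Nc3cccnn3)ccc21` has not yet been measured in this assay. It differs from compound 1 in one place: pyridazin-3-yl in place of pyrimidin-4-yl on a sulfonamide nitrogen. For the measured compounds named here, the single measured step, a number 1.20 log units higher from compound 1 to compound 2 (beyond the scatter), concerns a different part of the shared core, so no measured pair directly mirrors this change. The two groups have the same atoms, joined differently, so only a modest downward step, possibly within the scatter, is expected: a number 0.20 log units lower from compound 1 to compound 4 (within the scatter). Compound 4 is therefore estimated at 1.6, with a range from 1.1 to 2.1.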

Compound 4, distribution coefficient: 2.2
Compound 4: middle estimate off by 0.60 log units, on the low side, outside the stated range (above it).
By their numbers in this assay, from the lowest: compound 1; then compounds 3 and 4 (each within the scatter of the next); then compound 2.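

For the compounds shown here, on the sulfonamide nitrogen, pyridazin-3-yl in place of pyrimidin-4-yl gives, in this assay, a number 0.40 log units higher from compound 1 to compound 4 (beyond the scatter), a change measured here at this position for the first time. The two groups have the same atoms and the same counts of donors and acceptors, yet this rearrangement of ring atoms still moves the number beyond the scatter. Nothing available explains this step.

On these data alone, whether pyrazin-2-yl at this position would give a similar step remains open. So does whether this step would recur with 5-fluoropyridin-2-yl on the core, as in compound 2.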